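This account rests on a few compounds, and the source may have more. Where it says the series, first, only, none or still open, it means among the compounds named here.

In a functional assay on HeLa cells (Homo sapiens) for cytotoxicity, read by resazurin assay, with a stated time of 72 h (on this read-out lower numbers stand for stronger inhibition and higher numbers for weaker inhibition), compound 1 `CCOC(=O)SCC(=O)c1ccc(OC)cc1` gives 18500 nM, whereas compound 2 `CCSC(=S)SCC(=O)c1cccc(C(=O)Nc2ccccc2)c1` gives 2400 nM. That is the lower of the two numbers, and the gap between them lies beyond the scatter of repeated measurements. Compound 3 `CCSC(=S)SCC(=O)c1cccc(C(=O)NCc2ccccc2)c1` has not yet been measured in this assay. It departs from compound 2 at a single place: benzyl in place of phenyl on an amide-type nitrogen. Going by the values given here, no measured pair of compounds shows a step of this kind, so the expectation remains loose: no shift beyond the scatter, with a slight lean towards a higher number. The step expected is a 1.3-fold higher number from compound 2 to compound 3 (0.10 log units; within the scatter). For compound 3 the estimated value is 3000 nM, with an expected range from 1200 nM to 8000 nM.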

Compound 3, half-maximal inhibitory concentration: 13100 nM
Compound 3: the middle estimate sits 4.4-fold (0.64 log units) below what was measured, and the stated range ends below it.
By their numbers in this assay, from the lowest: compound 2; then compounds 3 and 1 (each within the scatter of the next).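

In this assay, going by these compounds alone, the group on the amide-type nitrogen turns out to matter on this core: benzyl in place of phenyl gives a 5.5-fold higher number from compound 2 to compound 3 (0.74 log units; beyond the scatter), a change the earlier compounds could not reveal. Both groups hold one six-membered aromatic ring of carbon only, and neither brings hydrogen-bond donors or acceptors, so a difference as small as the carbon that benzyl adds, anilino to benzylamino, is enough for a shift beyond the scatter. Nothing in the available data accounts for this shift.

The compounds shown leave open how a longer chain such as phenethyl, a methyl group on the same nitrogen or a fluorine on the phenyl ring would read out. On these data alone, with a single pair, it also remains open whether this step would recur on another core.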